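A few compounds are considered here, and "the series" means these few. Any claim that something is new, unique, unknown or untested is made for them only; others in the source may bear on it.

Compound 1, `COc1cc2c(cc1OC)C(CC(=O)O)CC2`, carries a hydroxy group on its carbonyl carbon. In a functional assay on the whole organism (strain Wistar) for inhibition, with Rattus norvegicus as the target, read by paw edema, with a stated time of 2 h, at a dose of 100 mg/kg (a higher number here means more inhibition at the dose given (going by the name of the read-out), a lower number less inhibition), compound 1 gives 24%, the lowest of the three numbers measured. Compound 2, `COc1cc2c(cc1OC)C(CC(=O)Nc1ccc(Cl)cc1)CC2`, gives 63% in this assay, and compound 3, `COc1cc2c(cc1OC)C(CC(=O)Nc1ccc(Br)cc1)CC2`, gives 40%. Both stand above compound 1 by more than the scatter: the step of a number 39 percentage points higher from compound 1 to compound 2 (beyond the scatter), and the step of a number 16 percentage points higher from compound 1 to compound 3 (beyond the scatter). Between the two larger compounds, the step of a number 23 percentage points lower from compound 2 to compound 3 (beyond the scatter) shows that the substituent on the entering ring changes the outcome.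

Compound 4, `COc1cc2c(cc1OC)C(CC(=O)Nc1ccc(C)cc1)CC2`, has not yet been measured. It differs from compound 1 in one place: (4-methylphenyl)amino in place of hydroxy on a carbonyl carbon. The two measured steps that bear on this change are those from compound 1 to compound 2 and from compound 1 to compound 3, each replacing the same hydroxy with an amino group bearing a ring with a different substituent, and each raising inhibition beyond the scatter, one by a large and one by a modest amount. A rise is therefore expected here as well, though its size is uncertain because a number 39 percentage points higher from compound 1 to compound 2 (beyond the scatter) and a number 16 percentage points higher from compound 1 to compound 3 (beyond the scatter) differ by more than the scatter. Compound 4 is estimated to show 45%, within 25% to 65%. This estimate corresponds to an expected step of a number 21 percentage points higher from compound 1 to compound 4 (beyond the scatter).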

Compound 4, a percentage reported as inhibition, in the whole organism at one dose (the size of the read-out at that dose, not a potency): 26%
Compound 4: the middle estimate sits 19 percentage points above what was measured, within the range that was stated.
By their numbers in this assay, from the lowest: compounds 1 and 4 (each within the scatter of the next); then compound 3; then compound 2.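

Placing an amide on the carbonyl carbon does not by itself raise the reading: in this assay the change to (4-methylphenyl)amino gives a number 2 percentage points higher from compound 1 to compound 4 (within the scatter) and so leaves the result level with the parent acid. The group on the entering ring therefore decides whether the swap for hydroxy pays off, as methyl falls short of both halogens, with a number 14 percentage points lower from compound 3 to compound 4 (beyond the scatter) and with a number 37 percentage points lower from compound 2 to compound 4 (beyond the scatter) in the same assay. The rises seen with chloro and bromo thus cannot be read as a general gain from attaching an aromatic ring through nitrogen, and nothing available here explains the differences among these three ring groups.

Going by these compounds, it remains open where an unsubstituted phenylamino group would fall, and whether fluoro, methoxy or trifluoromethyl on the ring would behave more like chloro, bromo or methyl. A simple amine or a saturated ring in place of the aromatic ring is also untested among the compounds shown, so the need for an aromatic ring at this place cannot be judged.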